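The source may report more compounds than this note shows. Statements on the series, on what has been measured and on what is new or still open speak of the compounds shown alone.

Measured so far:
compound 1, `Cc1cnc(Nc2ccc(S(C)(=O)=O)cc2)nc1Nc1nc2ccccc2s1`, with 460 nM in a functional assay on HeLa cells (Homo sapiens) for antiproliferative activity, read by MTT assay, with a stated time of 48 h; on this read-out higher numbers stand for weaker inhibition and lower numbers for stronger inhibition;
compound 2, `Cc1cnc(Nc2ccc(Cl)cc2)nc1Nc1nc2ccccc2s1`, with > 50000 nM.

In this assay compound 1 gives 460 nM. For compound 2 the assay reports only a limit and no number, namely > 50000 nM. Compound 2 thus sits at the limit of > 50000 nM in this assay, at which 1 of the 2 values shown sits. Among the compounds with values here, the single measured step, an at least 100-fold higher number from compound 1 to compound 2 (2.03 log units; beyond the scatter), exchanges one group on the phenyl ring of the shared core.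

Compound 3, `Cc1cnc(Nc2cccc(F)c2)nc1Nc1nc2ccccc2s1`, differs from compound 2 by 3-fluorophenyl in place of 4-chlorophenyl on a nitrogen on an aromatic ring. Within the data shown here, no measured step covers this particular exchange; the step from compound 1 to compound 2 concerns a different pair of groups, so it gives no direction for the present one. With compound 2 already at the limit, no change beyond the scatter is expected, which is what a number no higher from compound 2 to compound 3 (the limit leaves the size open) expresses. Compound 3 is therefore estimated at 50000 nM, in a range from 10000 nM to 200000 nM, and most probably reported again only as a limit.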

Compound 3, half-maximal inhibitory concentration: 16300 nM
Compound 3: middle estimate off by 3.1-fold (0.49 log units), on the high side, within the range that was stated.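

In this assay, the exchange of 4-chlorophenyl for 3-fluorophenyl on this nitrogen gives an at least 3.0-fold lower number from compound 2 to compound 3 (0.48 log units; beyond the scatter), so a change at this position that involves no methylsulfonyl group can also shift the result beyond the usual scatter. On these data alone, how large the shift really is stays unknown, since the value for compound 2 is only a limit: the limit of > 50000 nM in this assay, at which 1 of the 3 values shown sits. Two things change together in this step, the halogen and its place on the phenyl ring, and this pair cannot separate them.

A 3-chlorophenyl or a 4-fluorophenyl group would be needed to tell these two changes apart, and the compounds shown include neither. Also open, as far as these compounds go, is how an amine or a carboxylic acid on this phenyl ring would read in this assay.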